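Chloro for Methyl on a Biaryl Sulfonamide Core

This account rests on a few compounds, and the source may have more. Where it says the series, first, only, none or still open, it means among the compounds named here.

In a functional assay on J774 cells (Mus musculus) for cytotoxicity, read by resazurin assay, with a stated time of 72 h (a lower number here means a stronger inhibitor, a higher number a weaker inhibitor), compound 2 `Cc1ccc(-c2ccc(S(=O)(=O)Nc3cccc(CO)c3)cc2)cc1` gives 1200 nM, while compound 1 `O=S(=O)(Nc1cccc(CO)c1)c1ccc(-c2ccc(Cl)cc2)cc1` gives 2500 nM. The step of a 2.1-fold higher number from compound 2 to compound 1 (0.32 log units; beyond the scatter) comes from the change (chloro in place of methyl on an aromatic carbon). Compound 3 `Cc1ccc(CO)cc1NS(=O)(=O)c1ccc(-c2ccc(Br)cc2)cc1` shows in this assay only a limit, > 5000 nM, and no number, as the limit of > 5000 nM in this assay, at which 1 of the 3 values shown sits, records. The difference between the cores of compound 2 and compound 3 is not broken down here. Compound 4 `O=S(=O)(Nc1cc(CO)ccc1Cl)c1ccc(-c2ccc(Br)cc2)cc1` is not yet measured; it differs from compound 3 by chloro in place of methyl on an aromatic carbon, the same kind of change as from compound 2 to compound 1, though the place differs: ortho to a large group and para to a hydroxymethyl group rather than para to a large group. Because compound 3 already sits at the limit > 5000 nM, compound 4 is expected to stay weak, with an estimated step that the limit leaves unreadable from compound 3 to compound 4. The expected value for compound 4 is 12000 nM, between 4000 nM and 40000 nM.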

Compound 4, half-maximal inhibitory concentration: 2000 nM
The estimate for compound 4 lay 6.0-fold (0.78 log units) above the measured number; measured number below the stated range.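

In this assay chloro in place of methyl gives an at least 2.5-fold lower number from compound 3 to compound 4 (0.39 log units; beyond the scatter) on this core, while on the other core the same change moved the number the opposite way: the same change on two cores in this assay, a 2.1-fold higher number (0.32 log units; beyond the scatter) from compound 2 to compound 1 and an at least 2.5-fold lower number (0.39 log units; beyond the scatter) from compound 3 to compound 4, at least 5.2-fold (0.71 log units) apart, beyond the scatter of two such steps.
The value of compound 3, > 5000 nM here, is a limit and not a number.
So across these two pairs the change does not carry from one core to the other with a fixed direction, but the pairs do not show whether its place, ortho to a large group rather than para to a large group, or some other difference between the cores decides this.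

What the compounds shown leave open is how other groups would behave at the place of this change, such as fluoro, methoxy or an amine. Going by these compounds, it also stays open whether a carboxylic acid in place of the hydroxymethyl group would alter the result.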